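This account rests on a few compounds, and the source may have more. Where it says the series, first, only, none or still open, it means among the compounds named here.

Measured so far in a functional assay on RAW264.7 cells (Mus musculus) for inhibition, read by Griess assay, with stated times of 1 h and 24 h; a lower number here means a stronger inhibitor, a higher number a weaker inhibitor:

- compound 1 `CC(C)=CCOc1ccccc1C1CC(=O)c2ccccc2O1`: 32700 nM
- compound 2 `O=C1CC(c2ccccc2O)Oc2ccccc21`: 71300 nM
- compound 3 `COCOc1ccccc1C1CC(=O)c2ccccc2O1`: 32600 nM

Compound 3 stands level with compound 1 on these numbers, and both lie clear of compound 2. The next compound to be measured, compound 4 `CCOc1ccccc1C1CC(=O)c2ccccc2O1`, differs from compound 3 in one place: methyl in place of methoxy on a saturated chain carbon bound to an oxygen on an aromatic ring. That is methyl in place of methoxy on a saturated chain carbon bound to an oxygen on an aromatic ring, so methoxymethoxy becomes ethoxy.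

Within the data shown here, three measured steps bear on this change. The closest one exchanges the end of the chain at this same place, and compound 3 shows no real shift from compound 1: a 1.0-fold lower number from compound 1 to compound 3 (0.00 log units; within the scatter). The other two remove or add the whole group on the oxygen, and they are modest: a 2.2-fold higher number from compound 1 to compound 2 (0.34 log units; beyond the scatter), and a 2.2-fold lower number from compound 2 to compound 3 (0.34 log units; beyond the scatter). Compound 4 keeps a group on that oxygen and does not carry the hydrogen of compound 2, so it resembles compound 1 and compound 3 more closely. No step beyond the scatter is therefore expected in this assay.

For compound 4, the expected change is a 1.1-fold higher number from compound 3 to compound 4 (0.03 log units; within the scatter).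

The estimate for compound 4 is 35000 nM, with an expected range from 19000 nM to 65000 nM.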

Compound 4, half-maximal inhibitory concentration: 38500 nM
For compound 4 the middle estimate is 1.1-fold (0.04 log units) below the measured one; measured number inside the range.
By their numbers in this assay, from the lowest: compounds 3, 1, 4 and 2 (each within the scatter of the next, the first and the last beyond it).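

In this assay the swap of methoxy for methyl on a saturated chain carbon bound to an oxygen on an aromatic ring moves nothing beyond the scatter (a 1.2-fold higher number from compound 3 to compound 4 (0.07 log units; within the scatter)), and neither does the swap of 2-methylprop-1-en-1-yl for methyl at the same place (a 1.2-fold higher number from compound 1 to compound 4 (0.07 log units; within the scatter)), so three different chain ends now read alike here. The new comparison with the free hydrogen is also less clear than the earlier ones: ethyl in place of hydrogen on that oxygen stays within the scatter (a 1.9-fold lower number from compound 2 to compound 4 (0.27 log units; within the scatter)), whereas the larger groups of compound 1 and compound 3 each stood clear of compound 2, so any gain from a group on this oxygen is small and is not separated from hydrogen for every group. Nothing measured here accounts for this flat reading.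

On these data alone, what a chain ending in an amine or a carboxylic acid would do at this place remains open, as does the effect of a benzyl group on the same oxygen. As far as these compounds go, it is also open whether the same flat pattern would hold for changes elsewhere on the shared core.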